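Replacing the 2-chloro-4-fluorophenyl group of compound 3

The source may hold more compounds than are shown below. What is called first, only, known or untested is meant among the compounds shown, and "the series" means these compounds.

In a functional assay on A549 cells (Homo sapiens) for antiproliferative activity, read by MTT assay, with a stated time of 72 h (on this read-out lower numbers stand for stronger inhibition and higher numbers for weaker inhibition), compound 3 `O=C(N/N=C/c1ccc(F)cc1Cl)Nc1ccc(Oc2ccnc3[nH]ccc23)c(F)c1` gives 10 nM, the lowest number of the three, while compound 1 `O=C(N/N=C/c1ccc(Br)cc1)Nc1ccc(Oc2ccnc3[nH]ccc23)c(F)c1` gives 820 nM and compound 2 `O=C(N/N=C/c1cccc([N+](=O)[O-])c1)Nc1ccc(Oc2ccnc3[nH]ccc23)c(F)c1` gives 3640 nM. Compound 4 `CN(C)CCn1cccc1/C=N/NC(=O)Nc1ccc(Oc2ccnc3[nH]ccc23)c(F)c1` carries 1-(2-(dimethylamino)ethyl)-1H-pyrrol-2-yl in place of 2-chloro-4-fluorophenyl on a carbon with a double bond to nitrogen. All measured steps are changes at this same place. Two are large, an 82-fold lower number from compound 1 to compound 3 (1.91 log units; beyond the scatter) and a 360-fold lower number from compound 2 to compound 3 (2.56 log units; beyond the scatter), and one is modest, a 4.4-fold higher number from compound 1 to compound 2 (0.65 log units; beyond the scatter). Neither compound 1 nor compound 2 carries a pyrrole, so the guidance is indirect. A large rise is expected, an estimated 30-fold higher number from compound 3 to compound 4 (1.48 log units; beyond the scatter). Compound 4 is estimated at 300 nM, with an expected range of 40 nM to 2000 nM.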

Compound 4, half-maximal inhibitory concentration: "not active" (no number reported)
No number was reported for compound 4, so the estimate cannot be set against anything.
By their numbers in this assay, from the lowest: compound 3; then compound 1; then compound 2.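

Going by these compounds alone, compound 4 is reported as "not active" in this assay with no number, so no step from compound 3 to compound 4 can be read. Nothing shown accounts for this result. The compounds shown leave open how far the pyrrole-bearing group of compound 4 shifts the number.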